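Amide cap exchange on the shared bis-indole core

This account rests on a few compounds, and the source may have more. Where it says the series, first, only, none or still open, it means among the compounds named here.

Measured in a functional assay on MCF7 cells (Homo sapiens) for cytotoxicity, read by MTT assay, with a stated time of 72 h; a lower number here means a stronger inhibitor, a higher number a weaker inhibitor:
compound 1 `CN1[C@@H]2c3[nH]c4ccccc4c3C[C@H]1[C@H](C#N)N1[C@@H](CNC(=O)c3ccc(F)cc3)c3[nH]c4ccccc4c3C[C@@H]21`: 980 nM
compound 2 `CN1[C@@H]2c3[nH]c4ccccc4c3C[C@H]1[C@H](C#N)N1[C@@H](CNC(=O)c3cc4ccccc4[nH]3)c3[nH]c4ccccc4c3C[C@@H]21`: 9780 nM

In this assay compound 2 holds the higher of the two numbers, set apart from compound 1 by the step of a 10-fold higher number from compound 1 to compound 2 (1.00 log units; beyond the scatter). Compound 3 `COc1ccc(/C=C/C(=O)NC[C@H]2c3[nH]c4ccccc4c3C[C@H]3[C@H]4c5[nH]c6ccccc6c5C[C@@H]([C@H](C#N)N23)N4C)cc1` differs from compound 2 by 2-(4-methoxyphenyl)ethenyl in place of 1H-indol-2-yl on a carbonyl carbon. For the measured compounds named here, only one measured step bears on this position: a 10-fold higher number from compound 1 to compound 2 (1.00 log units; beyond the scatter) shows that swapping the group on this carbonyl carbon moved the number well beyond the scatter. A partial return toward the number of compound 1 is expected once the 1H-indol-2-yl group leaves. For compound 3 the estimated step is a 3.3-fold lower number from compound 2 to compound 3 (0.51 log units; beyond the scatter). Compound 3 is expected at 3000 nM, range 800 nM to 12000 nM.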

Compound 3, half-maximal inhibitory concentration: 4220 nM
Compound 3: the middle estimate sits 1.4-fold (0.15 log units) below what was measured; low and high end bracket the measured number.
By their numbers in this assay, from the lowest: compound 1; then compound 3; then compound 2.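

In this assay, the 2-(4-methoxyphenyl)ethenyl cap on this carbonyl carbon takes back only part of the rise seen with 1H-indol-2-yl (a 2.3-fold lower number from compound 2 to compound 3 (0.37 log units; beyond the scatter)) and does not return to the level of the 4-fluorophenyl cap (a 4.3-fold higher number from compound 1 to compound 3 (0.63 log units; beyond the scatter)). Among these three caps on the shared core, compound 1 therefore keeps the lowest number, and both replacements of 4-fluorophenyl raise it beyond the scatter. No measured evidence accounts for this order.

Going by these compounds, whether the ethenyl link or the methoxy group drives the step stays open, since both enter together. A 4-methoxyphenyl group placed directly on the carbonyl carbon would separate them, and a saturated alkyl chain there would test whether an aromatic ring is needed at all.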